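Swapping Chloro for Hydrogen on Compound 1

A few compounds are considered here, and "the series" means these few. Any claim that something is new, unique, unknown or untested is made for them only; others in the source may bear on it.

Values so far in a functional assay on A549 cells (Homo sapiens) for antiproliferative activity, read by sulforhodamine B assay, with a stated time of 48 h (on this read-out higher numbers stand for weaker inhibition and lower numbers for stronger inhibition), are these
Compound 1 `COc1ccc(C[C@@H](O)/C=C/C=C/C(=O)NCc2ccc(Cl)cc2)cc1OC` gives 16500 nM
Compound 2 `COc1ccc(C[C@@H](O)/C=C/C=C/C(=O)N2CCN(C(c3ccccc3)c3ccccc3)CC2)cc1OC` gives 10600 nM
Compound 3 `COc1ccc(C[C@@H](O)/C=C/C=C/C(=O)NCc2cc(OC)c(OC)c(OC)c2)cc1OC` gives 19200 nM

Compound 1 sits among these three values, and all of them lie within the usual scatter of one another, so they show no reliable order. Compound 4 `COc1ccc(C[C@@H](O)/C=C/C=C/C(=O)NCc2ccccc2)cc1OC` is still unmeasured. It differs from compound 1 by a single change (hydrogen in place of chloro on an aromatic carbon), hydrogen in place of chloro on an aromatic carbon. Among the compounds with values here, no measured pair isolates this change. Compound 2 (10600 nM) and compound 3 (19200 nM) carry very different groups on the shared core, yet both stay within the scatter of compound 1. No step beyond the scatter is therefore expected in this assay for this swap. The estimated 1.1-fold higher number from compound 1 to compound 4 (0.04 log units; within the scatter) lies within the scatter. For compound 4 the expected value is 18000 nM with 9000 nM to 35000 nM as the estimated range.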

Compound 4, half-maximal inhibitory concentration: 17100 nM
Compound 4: the middle estimate sits 1.1-fold (0.02 log units) above what was measured; the measured number falls inside the stated range.
By their numbers in this assay, from the lowest: compounds 2, 1, 4 and 3 (each within the scatter of the next).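

In this assay, hydrogen in place of chloro gives a 1.0-fold higher number from compound 1 to compound 4 (0.02 log units; within the scatter), so the chloro on this aromatic carbon, para to a large group, can be removed without a step beyond the scatter. Within the data shown here, this single-change pair reads that position directly, which the earlier compounds, differing from one another in more than one place, could not do. Nothing measured here offers an explanation for this result. On these data alone, whether an amine or a carboxylic acid at this same position would also stay within the scatter remains open.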